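The compounds below may be only part of what the source reports. "The series", "measured", "known", "first", "only" and "open" are said of these compounds alone.

Measured so far:
- compound 1, `O=S(=O)(Nc1ccc(-c2nc3cc(NS(=O)(=O)c4ccccc4O)ccc3o2)cc1)c1ccccc1O`: 18000 nM
- compound 2, `Cc1ccccc1S(=O)(=O)Nc1ccc2oc(-c3ccccc3)nc2c1`: > 100000 nM

In an assay on cells for inhibition of HSP60/HSP10 (Homo sapiens), with a stated time of 60 min (a lower number here means a stronger inhibitor, a higher number a weaker inhibitor), compound 1 gives 18000 nM. Compound 2 gives > 100000 nM in this assay, and this is a limit of the assay, not a number. Compound 2 therefore stands at the weak end of the two values shown, at the limit of > 100000 nM in this assay, at which 1 of the 2 values shown sits. Within the data shown here, no step between compound 1 and compound 2 is computed, since the two differ in more than one place, and their values are read only as they stand.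

Compound 3, `Cc1cccc(S(=O)(=O)Nc2ccc3oc(-c4ccccc4)nc3c2)c1`, is not yet measured in this assay. It differs from compound 2 by 3-methylphenyl in place of 2-methylphenyl on a sulfonyl sulfur. The methyl group on the ring attached to the sulfonyl sulfur thus changes its position, giving 3-methylphenyl where compound 2 carries 2-methylphenyl, with no change in atom count, donors or acceptors.

Nothing measured here shows such a change shifting this assay. The step of a number no higher from compound 2 to compound 3 (the limit leaves the size open) is expected to be none beyond the usual scatter. Compound 3 is expected to give 100000 nM in this assay, within 30000 nM to 300000 nM, most likely again as a limit rather than a number.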

Compound 3, half-maximal inhibitory concentration: > 100000 nM
Compound 3: only a limit was reported; the forecaster's own chance of this, stated with the estimate: 70%; the middle value lies on the limit itself.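

Compound 2 and compound 3 are both reported in this assay only as limits and not as numbers, so no step between them can be read: the limit of > 100000 nM in this assay, at which 2 of the 3 values shown sit.

The compounds shown leave open whether 3-methylphenyl in place of 2-methylphenyl on a sulfonyl sulfur changes the result in this assay at all.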